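A Methoxy Added to Compound 3

A few compounds are considered here, and "the series" means these few. Any claim that something is new, unique, unknown or untested is made for them only; others in the source may bear on it.

Compound 1 `COc1ccc2c(c1)-c1cnc(n1C)OCCCCCCCCO2` gives 63000 nM
Compound 2 `Cn1c2cnc1OCCCCCCCCCOc1ccccc1-2` gives 78000 nM
Compound 3 `C=CCCCCOc1ccccc1-c1cnc(OCCC=C)n1C` gives 33000 nM

All three numbers come from a functional assay on U-373MG ATCC cells (Homo sapiens) for inhibition, read by colorimetric assay and MTT assay, with a stated time of 72 h (a higher number here means a weaker inhibitor, a lower number a stronger inhibitor), and they show only weak inhibitors so far. Compound 3 lies within the usual scatter of compound 1. Compound 3 has a lower number than compound 2, and that gap lies outside the usual scatter.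

The next compound to be tested is compound 4 `C=CCCCCOc1ccc(OC)cc1-c1cnc(OCCC=C)n1C` which differs from compound 3 at one place. It has methoxy in place of hydrogen on an aromatic carbon and this carbon stands para to a (hex-5-en-1-yl)oxy group.

Among the compounds with values here, no measured pair shows this change alone, so the data offer no direct guide to its size in this assay and no firm direction. The measured numbers stay close together, from compound 3 (33000 nM) to compound 2 (78000 nM), so no large change is expected. The estimated 1.1-fold higher number from compound 3 to compound 4 (0.04 log units; within the scatter) stays within the scatter. Compound 4 is expected to give about 36000 nM (estimated range 15000 nM to 80000 nM).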

Compound 4, half-maximal inhibitory concentration: 67000 nM
Compound 4: the middle estimate sits 1.9-fold (0.27 log units) below what was measured; the measured number falls inside the stated range.
By their numbers in this assay, from the lowest: compounds 3, 1, 4 and 2 (each within the scatter of the next, the first and the last beyond it).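

In this assay, within the data shown here, putting methoxy in place of hydrogen on this aromatic carbon, para to a (hex-5-en-1-yl)oxy group, gives a 2.0-fold higher number from compound 3 to compound 4 (0.31 log units; beyond the scatter), the first step in this set that changes one place only. It shows that this position responds to substitution, and that a group of only 2 heavy atoms, with no ring and no net charge, modestly weakens inhibition here. No measurement shown gives a reason for this step.

One substituent at one position cannot show whether the loss belongs to methoxy or to any group placed there, so an amine, a fluorine atom or a longer ether chain on this carbon remains an open test. Going by these compounds, whether methoxy at this position acts the same way in compounds whose two chains are joined into a ring also stays open.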